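From chloro to methoxy on an aromatic carbon

The source may hold more compounds than are shown below. What is called first, only, known or untested is meant among the compounds shown, and "the series" means these compounds.

In a functional assay on L1210 cells (Mus musculus) for inhibition (on this read-out higher numbers stand for weaker inhibition and lower numbers for stronger inhibition), compound 1 (`Cc1cccc(/C=C2\CCc3ccccc3C2=O)c1`) gives 73200 nM while compound 2 (`O=C1CCCCC/C1=C\c1cccc(Cl)c1`) gives 144000 nM and the two values lie within the usual scatter of each other. Compound 2 therefore stands level with compound 1 on these numbers, and both show only weak inhibition in absolute terms.

For the measured compounds named here, the next compound, compound 3 (`COc1cccc(/C=C2\CCCCCC2=O)c1`), keeps the core of compound 2 and carries methoxy in place of chloro on an aromatic carbon as its only change. Going by the values given here, no measured pair of compounds differs in just one place, so the data offer no direct guide to this exchange. Among the compounds with values here, the only indication is that compound 1 at 73200 nM and compound 2 at 144000 nM remain close despite differing in more than one place. The expected step is a 1.1-fold lower number from compound 2 to compound 3 (0.04 log units; within the scatter) and no change beyond the scatter is anticipated in this assay in either direction. Compound 3 is expected to read 130000 nM with 50000 nM to 340000 nM as the estimated range.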

Compound 3, half-maximal inhibitory concentration: 283000 nM
Compound 3: the middle estimate sits 2.2-fold (0.34 log units) below what was measured; the measured number falls inside the stated range.
By their numbers in this assay, from the lowest: compounds 1, 2 and 3 (each within the scatter of the next, the first and the last beyond it).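

For the compounds shown here, compounds 2 and 3 form the first pair that differs in just one place, so this exchange can now be read directly rather than inferred from compounds that differ in more than one place. In this assay, replacing chloro with methoxy on an aromatic carbon of the six-membered aromatic ring gives a 2.0-fold higher number from compound 2 to compound 3 (0.29 log units; within the scatter), so the two groups cannot be told apart at this position, even though methoxy brings 2 heavy atoms and 1 hydrogen-bond acceptor where chloro brings 1 heavy atom and no hydrogen-bond acceptor. Nothing in the available data explains this outcome or connects it to any property of either group.

The compounds shown leave open whether a quite different substituent at this aromatic carbon, such as an amine, a carboxylic acid or a longer alkoxy chain, would move the number beyond the scatter, since chloro and methoxy are the only two groups compared there on this core. They also leave open whether the same exchange would read alike on the core of compound 1, which appears here with neither chloro nor methoxy.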